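This account rests on a few compounds, and the source may have more. Where it says the series, first, only, none or still open, it means among the compounds named here.

Values from a functional assay on HepG2 cells (Homo sapiens) for cytotoxicity, with a stated time of 24 h; a lower number here means a stronger inhibitor, a higher number a weaker inhibitor:
compound 1, `COc1cc(Cl)ccc1C(=O)Nc1ccc(Cl)cc1O`: 7340 nM
compound 2, `COc1cc(Cl)ccc1C(=O)Nc1ccc(Br)cc1O`: 46600 nM
compound 3, `COc1ccc(Cl)cc1C(=O)Nc1ccc(Cl)cc1O`: 51300 nM

Compound 1 and compound 2 share one core. Compound 3 is built from the same atoms joined differently, and the difference between the two cores is not broken down here. Compound 2 differs from compound 1 in a single place: bromo in place of chloro on an aromatic carbon. That change produced a 6.3-fold higher number from compound 1 to compound 2 (0.80 log units; beyond the scatter). Compound 3 carries the highest number of the three; its value and that of compound 2 lie within the usual scatter of each other, while its value and that of compound 1 lie well apart.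

Compound 4, `COc1ccc(Cl)cc1C(=O)Nc1ccc(Br)cc1O`, has not yet been measured in this assay. It differs from compound 3 by bromo in place of chloro on an aromatic carbon, the same change as from compound 1 to compound 2. Compound 4 is expected to give about 110000 nM. Its value is estimated to lie between 40000 nM and 350000 nM. Within the data shown here, the expected step of a 2.1-fold higher number from compound 3 to compound 4 (0.33 log units; beyond the scatter) rests on the single precedent because a 6.3-fold higher number from compound 1 to compound 2 (0.80 log units; beyond the scatter) is the only measured instance of this change, and compound 3 already sits at a high number, so the assay may report only a limit.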

Compound 4, half-maximal inhibitory concentration: 7980 nM
Beside the measured number, compound 4's estimate is 14-fold (1.14 log units) above it; the measured number lies below the stated range.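

In this assay, bromo in place of chloro on an aromatic carbon gave a 6.4-fold lower number from compound 3 to compound 4 (0.81 log units; beyond the scatter), the opposite direction to the step on the core of compound 1: the same change on two cores in this assay, a 6.3-fold higher number (0.80 log units; beyond the scatter) from compound 1 to compound 2 and a 6.4-fold lower number (0.81 log units; beyond the scatter) from compound 3 to compound 4, 41-fold (1.61 log units) apart, beyond the scatter of two such steps In this series, then, the effect of this change depends on the core that carries it, and a step measured on one of these two cores cannot be carried over to the other. Among these compounds, the two pairs do not show why the direction reverses, and with only two cores they cannot tell which direction, if either, would be the more usual on a further core.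

The compounds shown carry only chloro or bromo at this place, so it remains open how fluoro, methyl or a nitrile would behave on either core. On these data alone, it also remains open whether the reversal would persist if an amine took the place of the hydroxy group.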